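The source may hold more compounds than are shown below. What is called first, only, known or untested is meant among the compounds shown, and "the series" means these compounds.

Measured compounds: compound 1 `CCOc1ccccc1-c1ccc(-c2nc3cnccc3cc2C#N)cc1` gives 3.8; compound 2 `CC[C@@H](Nc1c(C#N)c(-c2ccc(-c3ncccc3C)cc2)nc2cnccc12)C(N)=O` gives 2; compound 3 `CC[C@@H](Nc1c(C#N)c(-c2ccc(-c3cccc(Cl)c3OC)cc2)nc2cnccc12)C(N)=O` gives 3.1.

In a physicochemical assay for lipophilicity, read by HPLC, at pH 7.5 (on this read-out lower numbers stand for lower lipophilicity and higher numbers for higher lipophilicity), compound 1 stands highest of the three, with compound 3 nearest below it and compound 2 furthest below. Compound 4 `CCOc1ccccc1-c1ccc(-c2nc3cnccc3c(NC(C(N)=O)C3CC3)c2C#N)cc1` differs from compound 1 by a group of 8 heavy atoms (5 carbon, 2 nitrogen, 1 oxygen; one three-membered non-aromatic ring of carbon only) in place of a hydrogen atom, on an aromatic carbon. Going by the values given here, the only measured step, a number 1.10 log units higher from compound 2 to compound 3 (beyond the scatter), swaps one aryl group for another and does not touch the position changed here, so no measured step bears directly on this change. What compounds 2 and 3 do show is that two compounds carrying a similar amide side chain both give lower numbers than compound 1. On that basis compound 4 is expected to give 3, between 2.3 and 3.7, a downward step of a number 0.80 log units lower from compound 1 to compound 4 (beyond the scatter).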

Compound 4, distribution coefficient: 3
For compound 4 middle estimate and measured number coincide at the digits printed; measured number inside the range.
By their numbers in this assay, from the lowest: compound 2; then compounds 4 and 3 (each within the scatter of the next); then compound 1.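

In this assay, this position now has a direct reading: the group of 8 heavy atoms, in place of a hydrogen atom on the aromatic carbon ortho to a cyano group, gives a number 0.80 log units lower from compound 1 to compound 4 (beyond the scatter). Compounds 2 and 3 carry a similar amide side chain but offered no matched comparison with hydrogen at this position. Nothing measured here accounts for the size of this step. From the compounds shown here alone, it remains open whether a plain amine, a carboxylic acid or a longer chain at this position would give a similar step. Going by these compounds, it also remains open whether the step would hold with 3-methylpyridin-2-yl or 3-chloro-2-methoxyphenyl as the aryl group.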